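The source may hold more compounds than are shown below. What is called first, only, known or untested is meant among the compounds shown, and "the series" means these compounds.

Measured so far:
compound 1, `CNC(=O)c1ccc(NC(=O)c2cn(Cc3c(F)cccc3F)c3ccc(=O)[nH]c3c2=O)cc1`, in an in vitro assay on Sf21 cells for inhibition of high affinity 3',5'-cyclic-AMP phosphodiesterase 7A (Homo sapiens), read by scintillation proximity assay, with a stated time of 30 min (a lower number here means a stronger inhibitor, a higher number a weaker inhibitor), compound 1 gives 29 nM;
compound 2, `O=C(Nc1ccc(OC(F)F)cc1)c1cn(Cc2c(F)cccc2F)c2ccc(=O)[nH]c2c1=O`, in this assay compound 2 gives 71 nM.

Among the compounds with values here, compound 2 holds the highest of the two numbers; its nearest neighbour is compound 1, and the one measured step, a 2.4-fold higher number from compound 1 to compound 2 (0.39 log units; beyond the scatter), separates them.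

Compound 3, `COc1cc(NC(=O)c2cn(Cc3c(F)cccc3F)c3ccc(=O)[nH]c3c2=O)cc(OC)c1`, has not been measured. Relative to compound 2 the change is 3,5-dimethoxyphenyl in place of 4-(difluoromethoxy)phenyl on an amide-type nitrogen. Within the data shown here, the only measured step, a 2.4-fold higher number from compound 1 to compound 2 (0.39 log units; beyond the scatter), exchanged a single substituent on the phenyl attached to the amide nitrogen and moved the number only modestly. Among the measured compounds shown here, the present change replaces that whole phenyl, so the one step bears on it only indirectly; it shows that variation at this end of the shared core gives modest movement, and nothing measured argues for a large shift in either direction. A step of at most modest size is expected in this assay, with the direction open.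

For compound 3 the expected value in this assay is 90 nM, with a range from 30 nM to 270 nM. The corresponding expected step is a 1.3-fold higher number from compound 2 to compound 3 (0.10 log units; within the scatter).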

Compound 3, half-maximal inhibitory concentration: 212 nM
Beside the measured number, compound 3's estimate is 2.4-fold (0.37 log units) below it; the range from low to high includes it.
By their numbers in this assay, from the lowest: compound 1; then compound 2; then compound 3.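

In this assay, exchanging the whole aryl group on the amide-type nitrogen gives a 3.0-fold higher number from compound 2 to compound 3 (0.48 log units; beyond the scatter), so this position responds to the 3,5-dimethoxyphenyl group beyond the scatter, and the direction left open earlier is now settled for this pair. Measured against the 4-(methylcarbamoyl)phenyl group, the same group gives a 7.3-fold higher number from compound 1 to compound 3 (0.86 log units; beyond the scatter), and the three compounds now form an order at this position, with compound 1 lowest and compound 3 highest, each step beyond the scatter. Nothing measured explains this order, and no supporting data bear on why the 3,5-dimethoxyphenyl group gives the highest number.

The compounds shown do not separate the effect of the substitution pattern from that of the substituent itself, since compound 3 changes both at once; a 4-methoxyphenyl or a 3-methoxyphenyl group would address that question. On these data alone, it also remains open whether the low number of compound 1 is specific to the methylcarbamoyl group or would carry over to a primary carboxamide, a carboxylic acid or an amine at the same place on the phenyl.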